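The compounds below may be only part of what the source reports. "The series", "measured", "known", "first", "only" and "open" are said of these compounds alone.

Compound 1: `O=C1NC(=O)/C(=C/c2ccc(OCCOC3CCCCC3)cc2Cl)S1` — 211 nM
Compound 2: `Cc1ncsc1CCOc1ccc(/C=C2\SC(=O)NC2=O)cc1Cl` — 5170 nM

Of the compounds shown here, two have been measured in an assay for inhibition of 15-hydroxyprostaglandin dehydrogenase [NAD(+)] (Homo sapiens), read by fluorescence and spectrophotometry; a lower number here means a stronger inhibitor, a higher number a weaker inhibitor. Compound 1 gives 211 nM in this assay, and compound 2 gives 5170 nM. For the measured compounds named here, of the two numbers, the one for compound 2 is the higher, and its gap to compound 1 lies well beyond the scatter of the assay; since compound 1 and compound 2 differ in more than one place, nothing more is drawn from that pair than what the two values show.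

Compound 3, `O=C1NC(=O)/C(=C/c2ccc(OCC3CCCC3)c(Cl)c2)S1`, has not yet been measured. It stands next to compound 2 through one change: cyclopentyl in place of (4-methyl-1,3-thiazol-5-yl)methyl on a saturated chain carbon bound to an oxygen on an aromatic ring. Going by the values given here, no step between measured compounds matches this change, so the expectation rests on the two values alone. Because compound 1 with 211 nM carries a plain carbocycle on its side chain and sits so far beneath compound 2, the author expects a step down, with the expected step from compound 2 to compound 3 being a 10-fold lower number from compound 2 to compound 3 (1.01 log units; beyond the scatter). Compound 3 is thus estimated at 500 nM, within a range of 120 nM to 2500 nM.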

Compound 3, half-maximal inhibitory concentration: 11 nM
For compound 3 the middle estimate is 45-fold (1.66 log units) above the measured one, and the stated range ends above it.
By their numbers in this assay, from the lowest: compound 3; then compound 1; then compound 2.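

In this assay, for the compounds shown here, the single change at this place, on a saturated chain carbon bound to an oxygen on an aromatic ring, gives a 470-fold lower number from compound 2 to compound 3 (2.67 log units; beyond the scatter), a large step that shows what this place carries can matter greatly. The two earlier compounds differ in more than one place, so their values could not tie any difference to one change, whereas this pair does so directly: cyclopentyl, a five-membered non-aromatic ring of carbon only, gives a far stronger inhibitor than (4-methyl-1,3-thiazol-5-yl)methyl, which holds a five-membered aromatic ring with 2 hetero atoms. Nothing at hand bears on why the step is so large, and one pair cannot separate the loss of the hetero atoms, the loss of the methyl group and the change in the ring.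

The compounds shown leave open how the number would move with a phenyl, cyclohexyl or isobutyl group on the same chain carbon. They also leave open whether a thiazol-5-yl group without its methyl group would stand closer to cyclopentyl or to the group that left.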